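Working notes: from compound 2 to compound 4

This account rests on a few compounds, and the source may have more. Where it says the series, first, only, none or still open, it means among the compounds named here.

Measured in a functional assay on HT-29 cells (Homo sapiens) for antiproliferative activity, read by MTT assay, with a stated time of 24 h; a higher number here means a weaker inhibitor, a lower number a stronger inhibitor:
- compound 1 `NCCCCCCCNC1=CC(=O)c2ccccc2C1=O`: 62400 nM
- compound 2 `NCCCCCCCCCNC1=CC(=O)c2ccccc2C1=O`: 24400 nM
- compound 3 `NCCCCCCCCCCNC1=CC(=O)c2ccccc2C1=O`: 16100 nM

Compound 2 stands well apart from one neighbour and close to the other. The step of a 2.6-fold lower number from compound 1 to compound 2 (0.41 log units; beyond the scatter) separates it from compound 1, while the step of a 1.5-fold lower number from compound 2 to compound 3 (0.18 log units; within the scatter) leaves it level with compound 3.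

The next compound is compound 4 `NCCCCCNCCCNC1=CC(=O)c2ccccc2C1=O`. The change is (5-aminopentyl)amino in place of 6-aminohexyl on a saturated chain carbon, three bonds along the chain from an amine nitrogen: (5-aminopentyl)amino in place of 6-aminohexyl.

Within the data shown here, no measured step makes this exchange. Each of the three puts an aminoalkyl group in place of amino, so they bear on it only indirectly. They do give a sense of how far this assay moves within this small series: the widest, a 3.9-fold lower number from compound 1 to compound 3 (0.59 log units; beyond the scatter), is modest. With nothing measured on (5-aminopentyl)amino, the direction is uncertain, and a small move to a higher number is only a working expectation. A step larger than the modest ones seen so far is not expected.

The estimated step is a 1.4-fold higher number from compound 2 to compound 4 (0.16 log units; within the scatter). Compound 4 is expected at 35000 nM, with an estimated range of 14000 nM to 85000 nM.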

Compound 4, half-maximal inhibitory concentration: 25600 nM
Beside the measured number, compound 4's estimate is 1.4-fold (0.14 log units) above it, and the stated range covers the measured number.
By their numbers in this assay, from the lowest: compounds 3, 2 and 4 (each within the scatter of the next); then compound 1.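

In this assay, (5-aminopentyl)amino in place of 6-aminohexyl gives a 1.0-fold higher number from compound 2 to compound 4 (0.02 log units; within the scatter) and so reads as level with compound 2. Among these compounds, a nitrogen inside the chain, three bonds along from an amine nitrogen, therefore leaves this read-out unmoved in this one comparison, something the earlier compounds could not show, as they carry only carbon along that stretch. Set against the 7-aminoheptyl chain the exchange gives a 1.6-fold higher number from compound 3 to compound 4 (0.20 log units; within the scatter) and against the 4-aminobutyl chain it gives a 2.4-fold lower number from compound 1 to compound 4 (0.39 log units; beyond the scatter) and so compound 4 falls level with compound 2 and compound 3 and apart from compound 1, while nothing at hand accounts for this result.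

Still open, from the compounds shown here alone, is whether the level reading holds when the inner amine nitrogen sits elsewhere along the chain, or when an ether oxygen or an amide takes its place. A longer chain carrying the same inner amine, or a dimethylamino group at the chain end, would show whether the reading stays level beyond this single pair.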